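The source may report more compounds than this note shows. Statements on the series, on what has been measured and on what is new or still open speak of the compounds shown alone.

Of the compounds shown here, three have been read in a functional assay on PC-3 cells (Homo sapiens) for inhibition, read by MTT assay, with a stated time of 72 h; on this read-out lower numbers stand for stronger inhibition and higher numbers for weaker inhibition. Compound 1 `CCC(=O)O[C@@H](/C(C)=C/[C@@H](C)c1oc(CC)c(C)c(=O)c1C)[C@H](C)[C@@H](OC(=O)CC(C)C)[C@@H](C)c1oc([C@@H](C)[C@@H](O)CC)c(C)c(=O)c1C` gives the lowest number of them, at 3000 nM. Compound 2 `CCc1oc([C@H](C)/C=C(\C)[C@H](OC(C)=O)[C@H](C)[C@@H](OC(=O)CC(C)C)[C@@H](C)c2oc([C@@H](C)[C@H](CC)OC(C)=O)c(C)c(=O)c2C)c(C)c(=O)c1C` is nearest at 7000 nM, and compound 3 `CCC(=O)[C@@H](C)c1oc([C@H](C)[C@@H]2O[C@](O)([C@@H](C)c3oc(CC)c(C)c(=O)c3C)[C@@H](C)[C@@H](O)[C@@H]2C)c(C)c(=O)c1C` lies furthest off at 82000 nM. Both gaps from compound 1 lie beyond the scatter. Compound 4 `CCc1oc([C@H](C)/C=C(\C)[C@H](O)[C@H](C)[C@@H](OC(=O)CC(C)C)[C@@H](C)c2oc([C@@H](C)[C@@H](O)CC)c(C)c(=O)c2C)c(C)c(=O)c1C`, not yet measured, differs from compound 1 in one place: hydrogen in place of propanoyl on an oxygen on a saturated carbon. For the measured compounds named here, no measured pair shows this change alone. A moderate rise in the number is expected, in the range of compound 2 at 7000 nM. The expected size is a 2.0-fold higher number from compound 1 to compound 4 (0.30 log units; within the scatter). The estimated value for compound 4 is 6000 nM, with an expected range of 2500 nM to 20000 nM.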

Compound 4, half-maximal inhibitory concentration: > 100000 nM
Compound 4: only a limit was reported; the forecaster's own chance of this, stated with the estimate: 10%; at least 16-fold (1.22 log units) between middle value and limit.
By their numbers in this assay, from the lowest: compound 1; then compound 2; then compound 3. At a limit, above all of these: compound 4.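

In this assay, for the compounds shown here, the propanoyl on this oxygen proves to count for far more than the earlier compounds could show: hydrogen in its place gives an at least 33-fold higher number from compound 1 to compound 4 (1.52 log units; beyond the scatter), the only step here that isolates this change. Compound 4 gives a limit and not a number, so the full size of the step stays unknown: the limit of > 100000 nM in this assay, at which 1 of the 4 values shown sits.

From the compounds shown here alone, it remains open whether a longer chain such as butanoyl, or a methyl ether on the same oxygen, would keep the value of compound 1 at 3000 nM.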